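The compounds below may be only part of what the source reports. "The series", "measured", "known", "first", "only" and "open" are said of these compounds alone.

In a functional assay on Jurkat cells (Homo sapiens) for activation, with a stated time of 24 h (a higher number here means that more compound is needed for the effect, a lower number that less compound is needed), compound 3 `Oc1ccccc1CNc1ccc(-c2cccc(F)c2)cc1` gives 2020 nM, and among the compounds examined it is the only one with a numerical result. Among the compounds with values here, compound 1 `Oc1ccc(CNc2ccc(C3CCCCC3)cc2)cc1` is reported in this assay as "not active" (no number reported), and compound 2 `Cc1cccc(CNc2ccc(C3CCCCC3)cc2)c1O` likewise as "not active" (no number reported); neither carries a number, so no step between measured compounds can be drawn. Compound 4 `Oc1ccccc1CNc1ccc(C2CCCCC2)cc1` differs from compound 3 by cyclohexyl in place of 3-fluorophenyl on an aromatic carbon. Within the data shown here, no measured pair shows this exchange, and the two compounds that already carry a cyclohexyl, compound 1 and compound 2, gave no activity. The step from compound 3 to compound 4 is therefore expected to go toward more compound being needed, by a 2.5-fold higher number from compound 3 to compound 4 (0.39 log units; beyond the scatter). For compound 4 an effective concentration of about 5000 nM is estimated, somewhere between 1500 nM and 20000 nM.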

Compound 4, half-maximal effective concentration: 8800 nM
The estimate for compound 4 lay 1.8-fold (0.25 log units) below the measured number; low and high end bracket the measured number.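

In this assay, this position keeps a measurable effect with a non-aromatic ring: cyclohexyl in place of 3-fluorophenyl gives a 4.4-fold higher number from compound 3 to compound 4 (0.64 log units; beyond the scatter), a modest step. Cyclohexyl alone therefore does not mean a missing number, as compound 4 has one, whereas compound 1 and compound 2, which also carry cyclohexyl, are reported without one. No available evidence explains the step. The compounds shown leave open how much of the step belongs to the fluorine and how much to the ring, which an unsubstituted phenyl would separate. As far as these compounds go, how a morpholine or a carboxylic acid would fare at this position also stays open.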